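Fluoro for Chloro on the Triazole Aryl Group

The compounds below may be only part of what the source reports. "The series", "measured", "known", "first", "only" and "open" are said of these compounds alone.

Of the compounds shown here, three sharing one core have been measured in a functional assay on A549 cells (Homo sapiens) for cytotoxicity, read by MTT assay, with a stated time of 4 days; on this read-out higher numbers stand for weaker inhibition and lower numbers for stronger inhibition. Compound 1 `C=C1C(=O)[C@]23C[C@@]1(O)CC[C@H]2c1ccc(OS(=O)(=O)c2ccc(C)cc2)c(C)c1[C@@H]3Cn1cc(-c2ccccn2)nn1` gives 2310 nM, compound 2 `C=C1C(=O)[C@]23C[C@@]1(O)CC[C@H]2c1ccc(OS(=O)(=O)c2ccc(C)cc2)c(C)c1[C@@H]3Cn1cc(-c2ccc(Cl)cc2)nn1` gives 1870 nM, and compound 3 `C=C1C(=O)[C@]23C[C@@]1(O)CC[C@H]2c1ccc(O)c(C)c1[C@@H]3Cn1cc(-c2ccc(Cl)cc2)nn1` gives 640 nM. Compound 2 stands second highest of the three numbers; its nearest neighbour is compound 1, within the scatter, and its furthest is compound 3, beyond it. The move from compound 1 to compound 2 shows a 1.2-fold lower number from compound 1 to compound 2 (0.09 log units; within the scatter), so swapping the aryl group on the triazole left the number essentially unchanged. The move from compound 2 to compound 3 shows a 2.9-fold lower number from compound 2 to compound 3 (0.47 log units; beyond the scatter), a modest gain on removing the sulfonyl ester.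

Compound 4 `C=C1C(=O)[C@]23C[C@@]1(O)CC[C@H]2c1ccc(OS(=O)(=O)c2ccc(C)cc2)c(C)c1[C@@H]3Cn1cc(-c2ccc(F)cc2)nn1` differs from compound 2 by fluoro in place of chloro on an aromatic carbon, placed para to a large group on the phenyl ring. Among the compounds with values here, the only step that bears on this change is the one from compound 1 to compound 2, which was within the scatter; the step from compound 2 to compound 3 concerns a different site and does not apply. No step larger than the scatter is therefore expected in this assay from this swap, in either direction. Compound 4 is expected to give about 2200 nM, with a range of 1100 nM to 4500 nM, meaning an expected step of a 1.2-fold higher number from compound 2 to compound 4 (0.07 log units; within the scatter) from compound 2 to compound 4.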

Compound 4, half-maximal inhibitory concentration: 1950 nM
Compound 4: middle estimate off by 1.1-fold (0.05 log units), on the high side; low and high end bracket the measured number.
By their numbers in this assay, from the lowest: compound 3; then compounds 2, 4 and 1 (each within the scatter of the next).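

The chloro group of the 4-chlorophenyl had not been varied before, and in this assay placing fluoro on the same aromatic carbon, para to a large group, gives a 1.0-fold higher number from compound 2 to compound 4 (0.02 log units; within the scatter) and so shows that the two halogens read alike here while the sulfonyl ester is in place. With a 1.2-fold lower number from compound 1 to compound 4 (0.07 log units; within the scatter) as well, the pyridin-2-yl, 4-chlorophenyl and 4-fluorophenyl compounds all lie within the scatter of one another, and none of these three aryl groups on the triazole stands apart in this assay. No supporting measurement is available to account for why these groups read alike.

Going by these compounds, whether a methoxy group, an amine or a carboxylic acid on this aromatic carbon would shift the number beyond the scatter remains open. Also open is whether fluoro would match chloro on the free hydroxyl form represented by compound 3 at 640 nM in this assay, as the fluoro compound shown still carries the sulfonyl ester.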